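From a Nitrile to a Cyanotriazole on the Core

The source may hold more compounds than are shown below. What is called first, only, known or untested is meant among the compounds shown, and "the series" means these compounds.

Compound 1, `CNc1nc(C#N)nc(NC2(C#N)CCCCC2)n1`, carries a cyano group on its core. In an in vitro assay on Sf21 cells for inhibition of high affinity 3',5'-cyclic-AMP phosphodiesterase 7A (Homo sapiens) (a lower number here means a stronger inhibitor, a higher number a weaker inhibitor), compound 1 gives only a limit of the assay, > 1000 nM, so where it stands is known just as that limit (the limit of > 1000 nM in this assay, at which 1 of the 2 values shown sits). Compound 2, `CNc1nc(NC2(C#N)CCCCC2)nc(OC)n1`, differs in one place, methoxy in place of cyano on an aromatic carbon; in this assay compound 2 gives 521 nM. For the measured compounds named here, the single measured step, an at least 1.9-fold lower number from compound 1 to compound 2 (0.28 log units; that floor lies within the scatter), has a floor that lies within the scatter, so it settles little about how this position answers to change.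

Compound 3, `CNc1nc(NC2(C#N)CCCCC2)nc(-n2cnc(C#N)n2)n1`, is not yet measured. It differs from compound 1 in one place: 3-cyano-1H-1,2,4-triazol-1-yl in place of cyano on an aromatic carbon. The entering group sits on an aromatic carbon of a six-membered aromatic ring with 3 nitrogen, between two ring nitrogen atoms. Going by the values given here, no measured step puts an aromatic ring there, so the step to compound 2 is the only bearing, and it is weak. Compound 3 is therefore expected near 1200 nM, with a range from 300 nM to 5000 nM. The expected step that the limit leaves unreadable from compound 1 to compound 3 is small, and a limit again seems quite possible.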

Compound 3, half-maximal inhibitory concentration: > 5000 nM
Compound 3 was reported as a limit; the forecaster's own chance of this, stated with the estimate: 50%; middle value at least 4.1-fold (0.61 log units) from the limit.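

In this assay this position now shows a step beyond the scatter, an at least 9.5-fold higher number from compound 2 to compound 3 (0.98 log units; beyond the scatter), when 3-cyano-1H-1,2,4-triazol-1-yl takes the place of methoxy. The aromatic carbon between two ring nitrogen atoms therefore does not treat all groups alike: compound 2, with methoxy, gives a measured value, whereas compound 3, with a five-membered aromatic ring on that carbon, reaches only a limit of the assay. Compound 3 stands at a limit and not at a number, and compound 1 also stands at a limit, so the step between them cannot be read: the limit of > 5000 nM in this assay, at which 1 of the 3 values shown sits.

The compounds shown leave open whether the ring or the nitrile on it goes with the weaker result, a question that an unsubstituted 1,2,4-triazol-1-yl group on the same carbon would address. They also leave open how an amine such as dimethylamino, or a longer ether such as ethoxy, would compare with methoxy at this position, and how far compound 1 and compound 3 really lie from each other.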